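A few compounds are considered here, and "the series" means these few. Any claim that something is new, unique, unknown or untested is made for them only; others in the source may bear on it.

Of the compounds shown here, two have so far been tested in an assay on isolated protein for inhibition of protein kinase C zeta type (Homo sapiens), with stated times of 1 h and 2.5 min, tested at 30 uM; a higher number here means more inhibition at the concentration tested (going by the name of the read-out), a lower number less inhibition. Compound 1 `CCOC(=O)c1c(-c2ccc(OC)c(OC)c2)csc1N(C)C` gives 60%. Compound 2 `CCOC(=O)c1c(-c2cccc(C)c2)csc1N` gives 77%, the highest of the two numbers and a step above compound 1 that lies beyond the usual scatter. Compound 3 `CCOC(=O)c1c(-c2cccc(F)c2)csc1N` has not yet been measured; it differs from compound 2 in one place: fluoro in place of methyl on an aromatic carbon. Among the compounds with values here, no measured pair shows this change, so its effect is not known from the data. The expected step is small, a number 9 percentage points lower from compound 2 to compound 3 (within the scatter), and need not exceed the scatter. In this assay compound 3 is therefore estimated at 68%, within a range from 45% to 85%.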

Compound 3, a percentage reported as inhibition, at one concentration (the size of the read-out at that concentration, not a potency): 38%
Beside the measured number, compound 3's estimate is 30 percentage points above it; the measured number lies below the stated range.
By their numbers in this assay, from the lowest: compound 3; then compound 1; then compound 2.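

In this assay, within the data shown here, fluoro in place of methyl on an aromatic carbon, meta to a large group, gives a number 39 percentage points lower from compound 2 to compound 3 (beyond the scatter) and so forms the first measured pair that differs in one place. The inhibition at the concentration tested therefore depends strongly on which group sits at this position, even though the heavy-atom count stays the same. From the compounds shown here alone, whether a chloro, a hydroxyl or an amine at this place would keep the inhibition of compound 2 remains open. Nothing measured here explains why this one change matters so much.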